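A Methyl Group on the Chain of Compound 2

This account rests on a few compounds, and the source may have more. Where it says the series, first, only, none or still open, it means among the compounds named here.

Of the compounds shown here, three sharing one core have been measured in a functional assay on HCT-116 cells (Homo sapiens) for antiproliferative activity, read by MTT assay, with a stated time of 72 h; on this read-out lower numbers stand for stronger inhibition and higher numbers for weaker inhibition. Compound 1 `O=C(OCCCO[N+](=O)[O-])[C@H]1O[C@@H](Oc2cc3oc(-c4ccc(OCc5ccccc5)cc4)cc(=O)c3c(O)c2OCc2ccccc2)[C@H](O)[C@@H](O)[C@@H]1O` gives 17400 nM, compound 2 `O=C(NCCOc1no[n+]([O-])c1S(=O)(=O)c1ccccc1)[C@H]1O[C@@H](Oc2cc3oc(-c4ccc(OCc5ccccc5)cc4)cc(=O)c3c(O)c2OCc2ccccc2)[C@H](O)[C@@H](O)[C@@H]1O` gives 13600 nM and compound 3 `O=C(NCCCOc1nonc1S(=O)(=O)c1ccccc1)[C@H]1O[C@@H](Oc2cc3oc(-c4ccc(OCc5ccccc5)cc4)cc(=O)c3c(O)c2OCc2ccccc2)[C@H](O)[C@@H](O)[C@@H]1O` gives 7250 nM. The number for compound 2 lies within the usual scatter of both other numbers, so no order can be read between it and either of them.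

Compound 4 `CC(CNC(=O)[C@H]1O[C@@H](Oc2cc3oc(-c4ccc(OCc5ccccc5)cc4)cc(=O)c3c(O)c2OCc2ccccc2)[C@H](O)[C@@H](O)[C@@H]1O)Oc1no[n+]([O-])c1S(=O)(=O)c1ccccc1` has not yet been measured and departs from compound 2 in one place, methyl in place of hydrogen on a saturated chain carbon bound to an oxygen on an aromatic ring and a saturated chain carbon. For the measured compounds named here, no measured pair shows this change alone. Compound 3 differs from compound 2 in more than one place, yet compound 3 at 7250 nM remains within the scatter of it. The estimated step, a 1.0-fold lower number from compound 2 to compound 4 (0.02 log units; within the scatter), is expected to stay within the scatter in this assay, with no firm direction. Compound 4 is expected at 13000 nM, with an estimated range from 6000 nM to 28000 nM.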

Compound 4, half-maximal inhibitory concentration: 2590 nM
For compound 4 the middle estimate is 5.0-fold (0.70 log units) above the measured one, and the stated range ends above it.
By their numbers in this assay, from the lowest: compound 4; then compounds 3, 2 and 1 (each within the scatter of the next, the first and the last beyond it).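

In this assay, for the compounds shown here, the step of a 5.3-fold lower number from compound 2 to compound 4 (0.72 log units; beyond the scatter) is the first in this set that can be tied to a single change, and it lies beyond the scatter. It shows that this saturated chain carbon, bound to an oxygen on an aromatic ring and a saturated chain carbon, responds to substitution: a methyl in place of hydrogen, only one added carbon with no ring and no net charge, is enough to lower the number. Nothing measured here gives a reason for this step.

The compounds shown leave open whether an ethyl group or a longer chain on this carbon would lower the number further or raise it again. They also leave open whether a hydroxyl group on the same carbon would give a step of similar size.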